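A Chloro Swapped for Amino, Awaiting Cytotoxicity Data

The source may hold more compounds than are shown below. What is called first, only, known or untested is meant among the compounds shown, and "the series" means these compounds.

Results so far in a functional assay on HepG2 cells (Homo sapiens) for cytotoxicity, read by MTT assay, with a stated time of 48 h (a lower number here means a stronger inhibitor, a higher number a weaker inhibitor), are:
- compound 1 `Cc1ccc2oc(-c3ccccc3Cl)cc(=O)c2c1` with 6230 nM
- compound 2 `Cc1cc(Cl)cc2c(=O)cc(-c3ccc(Cl)cc3)oc12` with "not determined" (no result reported)

Compound 2 therefore stands nowhere on the scale, with no single number to compare. Compound 3 `Cc1cc(Cl)cc2c(=O)cc(-c3ccc(N)cc3)oc12` has no result yet. The change amino in place of chloro on an aromatic carbon puts amino in place of chloro on an aromatic carbon, para to a large group. Among the measured compounds shown here, with no number for compound 2, no step can be sized from it, so the expectation rests on the level of compound 1 (6230 nM), the only number available. Compound 3 is estimated at 7000 nM (expected range 2000 nM to 25000 nM).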

Compound 3, half-maximal inhibitory concentration: 11900 nM
The estimate for compound 3 lay 1.7-fold (0.23 log units) below the measured number, within the range that was stated.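

Among the compounds shown here, compound 2 has no single number in this assay, so no step from it to compound 3 can be read. The compounds shown leave open how amino in place of chloro bears on cytotoxicity, and no evidence at hand accounts for the result.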